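Allyloxy aryl pyridyl ketones: dropping the fluoro substituent

The source may report more compounds than this note shows. Statements on the series, on what has been measured and on what is new or still open speak of the compounds shown alone.

Measured compounds:
compound 1 `C=CCOc1ccc(F)cc1C(=O)c1cccnc1`; compound 1 gives > 100000 nM, a limit of the assay.
compound 2 `O=C(c1cccnc1)c1cc(F)ccc1O`; compound 2 gives 11800 nM.
compound 3 `O=C(c1cccnc1)c1cccc(Cl)c1O`; compound 3 gives 31500 nM.

In a functional assay on PC-3 cells (Homo sapiens) for cytotoxicity, read by sulforhodamine B assay, with a stated time of 48 h (a lower number here means a stronger inhibitor, a higher number a weaker inhibitor), compound 1 sits at the limit of the assay and gives no number (the limit of > 100000 nM in this assay, at which 1 of the 3 values shown sits). Compound 4 `C=CCOc1ccccc1C(=O)c1cccnc1` differs from compound 1 by hydrogen in place of fluoro on an aromatic carbon. Within the data shown here, the only measured step, an at least 8.4-fold lower number from compound 1 to compound 2 (0.92 log units; beyond the scatter), concerns the allyl group on oxygen and does not bear on the fluoro position, so no measured step informs this change. The allyloxy group that compound 1 carries stays in compound 4. Compound 4 is therefore expected to stay at or near the limit, with a step that the limit leaves unreadable from compound 1 to compound 4 as the expected step. The estimate for compound 4 is 150000 nM, in the range 40000 nM to 600000 nM.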

Compound 4, half-maximal inhibitory concentration: 55000 nM
For compound 4 the middle estimate is 2.7-fold (0.44 log units) above the measured one; the measured number falls inside the stated range.
By their numbers in this assay, from the lowest: compound 2; then compounds 3 and 4 (each within the scatter of the next). At a limit, above all of these: compound 1.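

In this assay compound 4 gives 55000 nM, so an allyloxy group on the core does not by itself rule out a measured number. Compound 1 gives > 100000 nM, which is a limit and not a number: the limit of > 100000 nM in this assay, at which 1 of the 4 values shown sits. Hydrogen in place of fluoro, para to an allyloxy group, gives an at least 1.8-fold lower number from compound 1 to compound 4 (0.25 log units; that floor lies within the scatter), so the true size of this change stays unread.

Still open, going by these compounds, is how an amine or a methoxy group would read at this position. Also open, on these data alone, is what a longer chain in place of allyl would give on the core of compound 4.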